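The source may hold more compounds than are shown below. What is called first, only, known or untested is meant among the compounds shown, and "the series" means these compounds.

In a functional assay on K562 cells (Homo sapiens) for antiproliferative activity, read by MTT assay, with a stated time of 48 h (a higher number here means a weaker inhibitor, a lower number a stronger inhibitor), compound 1 (`COc1ccc(-c2ccc3c(c2)C(=O)C(=O)N3Cc2cccc(OC)c2)cc1`) gives 680 nM, compound 2 (`COc1ccc(CN2C(=O)C(=O)c3cc(-c4cccc(OC)c4)ccc32)cc1`) gives 100 nM and compound 3 (`COc1ccc(CN2C(=O)C(=O)c3cc(-c4cc(OC)cc(OC)c4)ccc32)cc1`) gives 510 nM. The numbers for compound 3 and compound 1 lie within the usual scatter of each other, and both are higher than the number for compound 2.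

Compound 4 (`COc1ccc(CN2C(=O)C(=O)c3cc(-c4ccc(C(C)(C)C)cc4)ccc32)cc1`) has 4-(tert-butyl)phenyl in place of 3,5-dimethoxyphenyl on an aromatic carbon. Going by the values given here, only one measured step bears on this change. It is a 5.1-fold higher number from compound 2 to compound 3 (0.71 log units; beyond the scatter), a modest rise that came with methoxy in place of hydrogen on an aromatic carbon. Compound 4 has no methoxy on this ring, which points towards a lower number. However, no measured compound carries tert-butyl, so that step is a weak guide. Only a small fall is therefore expected in this assay, and the expected step is a 1.7-fold lower number from compound 3 to compound 4 (0.23 log units; within the scatter). Compound 4 is estimated at 300 nM, with an expected range of 80 nM to 1000 nM.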

Compound 4, half-maximal inhibitory concentration: 2250 nM
Compound 4: the middle estimate sits 7.5-fold (0.88 log units) below what was measured; measured number above the stated range.
By their numbers in this assay, from the lowest: compound 2; then compounds 3 and 1 (each within the scatter of the next); then compound 4.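

In this assay, replacing 3,5-dimethoxyphenyl with 4-(tert-butyl)phenyl gives a 4.4-fold higher number from compound 3 to compound 4 (0.64 log units; beyond the scatter), and replacing 3-methoxyphenyl with it gives a 23-fold higher number from compound 2 to compound 4 (1.35 log units; beyond the scatter). Losing the methoxy groups from this ring therefore does not by itself lower the number, and among these three groups on this aromatic carbon, 3-methoxyphenyl in compound 2 gives the lowest number. The data shown offer no measured explanation for why the tert-butyl compound sits highest.

The compounds shown cannot separate the effect of adding tert-butyl from that of removing methoxy, since both changes occur together. They also leave open how a plain phenyl ring, or a phenyl ring carrying an amine or a carboxylic acid, would behave at this place.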